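Fluoro for ethyl on the fused ring, antiproliferative read-out

The source may report more compounds than this note shows. Statements on the series, on what has been measured and on what is new or still open speak of the compounds shown alone.

Two compounds of the series have numbers in a functional assay on A-375 cells (Homo sapiens) for antiproliferative activity, read by MTT assay, with a stated time of 24 h, tested at 0.05 ug/mL; on this read-out lower numbers stand for a weaker effect and higher numbers for a stronger effect at the one concentration tested. Compound 1 `Cc1c(C(=O)Nc2c(F)cc(-c3cccc(F)c3)cc2F)nc2ccc(F)cc2c1O` gives 0.05% in this assay. Compound 2 `CCc1ccc2nc(C(=O)Nc3c(F)cc(-c4cccc(F)c4)cc3F)c(C)c(C(=O)O)c2c1` gives 0.95% in this assay. Compound 2 is numerically the higher of the two, but the gap to compound 1 lies within the usual scatter, so the two numbers cannot be told apart; both sit near the floor of the read-out.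

Compound 3 `Cc1c(C(=O)Nc2c(F)cc(-c3cccc(F)c3)cc2F)nc2ccc(F)cc2c1C(=O)O` is the next member to be measured. Its difference from compound 2 is fluoro in place of ethyl on an aromatic carbon. Going by the values given here, no pair of measured compounds differs in one place, so no measured step gives a direct guide to the size of this change.

Because compound 1 gives 0.05% and compound 2 gives 0.95% in this assay, both near zero, no step beyond the scatter is expected from compound 2 to compound 3 in this assay, in either direction. The expected step is a number 0.5 percentage points lower from compound 2 to compound 3 (within the scatter). For compound 3 the estimate in this assay is 0.5%, within a range from 0% to 6%.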

Compound 3, a percentage reported as inhibition, at one concentration (the size of the read-out at that concentration, not a potency): 0.37%
Compound 3: middle estimate off by 0.1 percentage points, on the high side, and the stated range covers the measured number.
By their numbers in this assay, from the lowest: compounds 1, 3 and 2 (each within the scatter of the next).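

In this assay, going by these compounds alone, fluoro in place of ethyl on an aromatic carbon, meta to a fused ring and para to a fused ring, comes out as a number 0.6 percentage points lower from compound 2 to compound 3 (within the scatter), which gives the first one-place step at this position and leaves the two compounds indistinguishable. Carboxy in place of hydroxy on an aromatic carbon, a second place in the series, comes out as a number 0.3 percentage points higher from compound 1 to compound 3 (within the scatter), so neither exchange separates its pair at the one concentration tested, and all three compounds remain near the floor of the read-out. No supporting measurement is available to account for these results.

At this floor, the compounds shown leave open whether either place can influence this assay at all, since a step that stays within the scatter here gives no measure of how much each group contributes. From the compounds shown here alone, it also remains open whether an amine or a methoxy group on the fused-ring carbon, or a methyl ester or primary amide in place of the carboxy group, would give a number clear of the scatter.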